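Swapping the aryl group on the shared core of compound 2

The source may report more compounds than this note shows. Statements on the series, on what has been measured and on what is new or still open speak of the compounds shown alone.

Measured so far:
compound 1 `Cc1nc(-c2cccc3ccccc23)sc1COc1ccc2c(c1)OCC2CC(=O)O` gives 8.53% in a functional assay on CHO cells for agonist activity at Free fatty acid receptor 1 (Homo sapiens), read by FLIPR and calcium flux, tested at 100 nM; on this read-out higher numbers stand for a stronger effect at the one concentration tested and lower numbers for a weaker effect
compound 2 `Cc1nc(-c2ccc(Cl)cc2)sc1COc1ccc2c(c1)OCC2CC(=O)O` gives 53.4% in this assay

Among the measured compounds shown here, compound 2 holds the higher of the two numbers; the only measured step, a number 44.9 percentage points higher from compound 1 to compound 2 (beyond the scatter), lies beyond the scatter. Compound 3 `Cc1nc(-c2ccccc2F)sc1COc1ccc2c(c1)OCC2CC(=O)O` differs from compound 2 by 2-fluorophenyl in place of 4-chlorophenyl on an aromatic carbon. For the measured compounds named here, no measured step swaps one six-membered aromatic ring for another of the same size, so that large step bears on this change only loosely. A moderate drop in this assay is expected, a number 18.4 percentage points lower from compound 2 to compound 3 (beyond the scatter); compound 3 is estimated at 35%, between 10% and 60%.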

Compound 3, a percentage reported as activity, at one concentration (the size of the read-out at that concentration, not a potency): 25.8%
The estimate for compound 3 lay 9.2 percentage points above the measured number; low and high end bracket the measured number.
By their numbers in this assay, from the lowest: compound 1; then compound 3; then compound 2.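

Even with the heavy-atom count unchanged, swapping one halogen-bearing phenyl group for another moves the result in this assay, with a number 27.6 percentage points lower from compound 2 to compound 3 (beyond the scatter), so this position distinguishes between single phenyl rings and not only between them and naphthalen-1-yl. The 2-fluorophenyl group also differs clearly from naphthalen-1-yl, with a number 17.3 percentage points higher from compound 1 to compound 3 (beyond the scatter). Nothing available explains either step. Because both the halogen and its place on the ring change together, their contributions cannot be separated here; 4-fluorophenyl or 2-chlorophenyl would pull them apart.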